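Moving the methoxy group in a piperidine sigma ligand

This account rests on a few compounds, and the source may have more. Where it says the series, first, only, none or still open, it means among the compounds named here.

Compound 2 `COc1ccc(C(C)CCN2CCC(Cc3ccccc3)CC2)cc1` gives the lowest number of the three compounds measured in an assay on membranes from Cerebral cortex for displacement of a labelled ligand from Sigma non-opioid intracellular receptor 1 (Cavia porcellus), read by scintillation counting, with a stated time of 120 min (on this read-out higher numbers stand for weaker inhibition and lower numbers for stronger inhibition), at 3.5 nM. Its parent, compound 1 `COc1ccc(C(C)CCN2CCCCC2)cc1`, gives 20 nM in this assay, and the benzyl added on a saturated ring carbon brought a 5.7-fold lower number from compound 1 to compound 2 (0.76 log units; beyond the scatter). Compound 3 `CC(CCN(C)C)c1ccccc1`, which lacks both the methoxy group and the piperidine, gives 427 nM in this assay, far weaker than compound 2.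

Compound 4 `COc1cccc(C(C)CCN2CCC(Cc3ccccc3)CC2)c1` keeps every atom of compound 2 but joins them differently: 3-methoxyphenyl in place of 4-methoxyphenyl on a saturated chain carbon bound to two saturated chain carbons. Among the measured compounds shown here, none of the measured steps touches the aromatic ring, so nothing in the set speaks directly to this change; the only step measured, from compound 1 to compound 2, concerns the piperidine end of the molecule. The relocation of the methoxy group is therefore expected to bring a step of a 1.4-fold higher number from compound 2 to compound 4 (0.15 log units; within the scatter) in this assay, most likely within the scatter or a slight weakening. Compound 4 is expected to give about 5 nM, within a range from 1.5 nM to 16 nM.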

Compound 4, inhibition constant: 2.9 nM
Compound 4: middle estimate off by 1.7-fold (0.24 log units), on the high side; the measured number falls inside the stated range.
By their numbers in this assay, from the lowest: compounds 4 and 2 (each within the scatter of the next); then compound 1; then compound 3.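

The move of the methoxy group brought a 1.2-fold lower number from compound 2 to compound 4 (0.08 log units; within the scatter) in this assay, the first measured change on the aromatic ring, and it is the only step shown at this position. With 3-methoxyphenyl or 4-methoxyphenyl on a saturated chain carbon bound to two saturated chain carbons, the two benzyl-bearing compounds cannot be told apart on this read-out, so the binding number here does not depend measurably on which of these two methoxyphenyl groups is present. No evidence is available that bears on this result.

The compounds shown leave open whether a hydroxyl group or a chlorine atom in place of the methoxy group would keep the number in this range. They also leave open whether 3-methoxyphenyl would match 4-methoxyphenyl on the core of compound 1, which lacks the benzyl.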